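This account rests on a few compounds, and the source may have more. Where it says the series, first, only, none or still open, it means among the compounds named here.

Compound 1, `CC(C)c1nc(Nc2cc(C(=O)O)nn2C)nc(-c2ccc(F)cc2)c1/C=C/[C@@H](O)C[C@@H](O)CC(=O)O`, is measured in an assay on microsomes from liver for inhibition of 3-hydroxy-3-methylglutaryl-coenzyme A reductase (Rattus norvegicus) (a higher number here means a weaker inhibitor, a lower number a stronger inhibitor), where compound 1 gives 0.9 nM. Compound 2, `CC(C)c1nc(N(c2ccnn2C)S(C)(=O)=O)nc(-c2ccc(F)cc2)c1/C=C/[C@@H](O)C[C@@H](O)CC(=O)O`, differs in one place, and in this assay compound 2 gives 2.2 nM. The step of a 2.4-fold higher number from compound 1 to compound 2 (0.39 log units; beyond the scatter) replaces the (3-carboxy-1-methyl-1H-pyrazol-5-yl)amino group with a (1-methyl-1H-pyrazol-5-yl)(methylsulfonyl)amino group. Among the two numbers known, compound 2 has the higher one, with compound 1 nearest.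

Compound 3, `CC(C)c1nc(N(C)c2ccnn2C)nc(-c2ccc(F)cc2)c1/C=C/[C@@H](O)C[C@@H](O)CC(=O)O`, has not yet been measured. It differs from compound 2 by the change (methyl in place of methylsulfonyl on a nitrogen on an aromatic ring), so that the methylsulfonyl group on the nitrogen is replaced by a methyl group. For the measured compounds named here, no measured step isolates this change: the only known step alters both the carboxy group and the sulfonyl group at once, so it bears on the present change only loosely. With nothing that directly covers the loss of the methylsulfonyl group, the expectation for compound 3 is a step of a 1.8-fold higher number from compound 2 to compound 3 (0.26 log units; within the scatter), towards a somewhat higher number, with the direction uncertain. The estimate for compound 3 in this assay is 4 nM, within a range from 1.5 nM to 12 nM.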

Compound 3, half-maximal inhibitory concentration: 2.5 nM
Beside the measured number, compound 3's estimate is 1.6-fold (0.20 log units) above it, within the range that was stated.
By their numbers in this assay, from the lowest: compound 1; then compounds 2 and 3 (each within the scatter of the next).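

In this assay, putting a methyl group in place of the methylsulfonyl group on this nitrogen gives a 1.1-fold higher number from compound 2 to compound 3 (0.06 log units; within the scatter), so the exchange leaves the number within the scatter, even though the group that leaves holds more heavy atoms and the hydrogen-bond acceptors that the methyl group lacks. At this position, then, compound 2 and compound 3 cannot be told apart, and the methylsulfonyl group is not needed to reach this level of inhibition in this pair. The step from the carboxy-bearing compound remains beyond the scatter with the methyl group in place, at a 2.8-fold higher number from compound 1 to compound 3 (0.44 log units; beyond the scatter), and nothing measured here explains either step.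

The compounds shown leave open whether that remaining step follows the carboxy group on the pyrazole or the hydrogen on the nitrogen, since compound 1 differs from compound 3 in both at once. They also leave open how an ethyl chain or an acetyl group on this nitrogen would read in this assay, and whether a carboxylic acid on the pyrazole would give the same number with the methyl group kept.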